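A methyl added to an anilide already beyond the limit

The source may hold more compounds than are shown below. What is called first, only, known or untested is meant among the compounds shown, and "the series" means these compounds.

Compound 2 (`O=C(Nc1ccccc1)c1csc(-c2c[nH]c3ccccc23)n1`) is one of two amide analogues of a shared core examined in a functional assay on PC-3 cells (Homo sapiens) for cytotoxicity, read by MTT assay, with a stated time of 48 h, in the absence of a further agent; on this read-out higher numbers stand for weaker inhibition and lower numbers for stronger inhibition. In this assay compound 2 gives only a limit, > 100000 nM, and no number. Its neighbour compound 1 (`O=C(NCc1ccccc1)c1csc(-c2c[nH]c3ccccc23)n1`) likewise gives only a limit in this assay, > 100000 nM. The change between them, phenyl in place of benzyl on an amide-type nitrogen, is therefore a step that the two limits leave unreadable from compound 1 to compound 2. Both values sit at the limit of > 100000 nM in this assay, at which 2 of the 2 values shown sit, so compound 2 stands at the edge of what this assay can report, with nothing measured to rank it against.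

Compound 3 (`Cc1ccc(NC(=O)c2csc(-c3c[nH]c4ccccc34)n2)cc1`) differs from compound 2 by methyl in place of hydrogen on an aromatic carbon. Going by the values given here, the only measured step that bears on this change, a step that the two limits leave unreadable from compound 1 to compound 2, gives no readable size, so no direction can be taken from it. The entering methyl is not expected to carry the value of compound 2 from beyond the limit into the measurable range. The expected a number no higher from compound 2 to compound 3 (the limit leaves the size open) is therefore no larger than the scatter. Compound 3 is estimated at 100000 nM, with a range from 30000 nM to 300000 nM, and most likely reported again only as a limit.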

Compound 3, half-maximal inhibitory concentration: > 100000 nM
Compound 3: only a limit was reported; the forecaster's own chance of this, stated with the estimate: 85%; the middle value sits exactly at the limit.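

In this assay compound 3 gives > 100000 nM as a limit and no number. With compound 1 and compound 2 also given only as limits, no step among these three compounds can be read. The compounds shown leave open whether any change on the amide nitrogen of the shared core would bring a value into the measurable range.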